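Compound 2 to compound 3: swapping the aromatic substituent

This account rests on a few compounds, and the source may have more. Where it says the series, first, only, none or still open, it means among the compounds named here.

Measured so far in a functional assay on A549 cells (Homo sapiens) for antiproliferative activity, read by MTT assay, with a stated time of 48 h (on this read-out lower numbers stand for stronger inhibition and higher numbers for weaker inhibition), for the series:
- compound 1 `N#Cc1nc2c(-c3nc4ccccc4o3)c(N)n(CCCN3CCCCC3)c2nc1C#N` gives 8670 nM here
- compound 2 `CN(C)CCCCn1c(N)c(-c2nc3ccccc3o2)c2nc(C#N)c(C#N)nc21` gives 5470 nM here

Among the measured compounds shown here, the only measured step is a 1.6-fold lower number from compound 1 to compound 2 (0.20 log units; within the scatter) and it leaves compound 2 level with compound 1 within the scatter. Compound 3 `CN(C)CCCCn1c(N)c(-c2nc3cc(Cl)ccc3[nH]2)c2nc(C#N)c(C#N)nc21` keeps the 4-(dimethylamino)butyl group of compound 2. The change to compound 3 is 5-chloro-1H-benzimidazol-2-yl in place of 1,3-benzoxazol-2-yl on an aromatic carbon and it sits on an aromatic carbon, next to the ring atom that bears an amino group. For the measured compounds named here, the measured step lies on the chain, so no measured step bears on this place and the range stays wide. No step beyond the scatter is expected in this assay and any lean is slight, towards a lower number. The expected step is a 1.4-fold lower number from compound 2 to compound 3 (0.14 log units; within the scatter) on this reading. Compound 3 is estimated at 4000 nM with 1000 nM to 12000 nM as the expected range.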

Compound 3, half-maximal inhibitory concentration: 12100 nM
Beside the measured number, compound 3's estimate is 3.0-fold (0.48 log units) below it; measured number above the stated range.
By their numbers in this assay, from the lowest: compounds 2, 1 and 3 (each within the scatter of the next, the first and the last beyond it).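

In this assay, among the compounds shown here, the change at this aromatic carbon, next to the ring atom that bears an amino group, gives a 2.2-fold higher number from compound 2 to compound 3 (0.34 log units; beyond the scatter) and so moves the number beyond the scatter, modestly, whereas the only earlier step, on the chain, stayed within it. The entering 5-chloro-1H-benzimidazol-2-yl differs from 1,3-benzoxazol-2-yl in two ways at once, a ring nitrogen carrying hydrogen in place of the ring oxygen and an added chlorine, so this step cannot be divided between them. Nothing measured here accounts for the step.

Open, from the compounds shown here alone, is where the unsubstituted 1H-benzimidazol-2-yl group would fall relative to compound 2 and compound 3, which would separate the share of the chlorine from that of the ring change. Also open, going by these compounds, is whether a fluorine or methoxy group in the place of the chlorine would shift the number, and whether the step carries over to the chain of compound 1.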